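A few compounds are considered here, and "the series" means these few. Any claim that something is new, unique, unknown or untested is made for them only; others in the source may bear on it.

Going by the values given here, the two compounds measured so far share one core and differ only in the group on an aromatic carbon of a six-membered aromatic ring of carbon only. Compound 1 `CN(C)c1ccc(-c2nc3c(=O)n(C)c(=O)n(C)c3[nH]2)cc1` carries a dimethylamino group there, and in an assay for binding affinity to adenosine receptor A1 (Bos taurus) (a lower number here means a stronger inhibitor, a higher number a weaker inhibitor), compound 1 gives 1.8 nM. Compound 2 `Cn1c(=O)c2nc(-c3ccc(I)cc3)[nH]c2n(C)c1=O` carries an iodo group at the same carbon, and in this assay compound 2 gives 1.3 nM. The step of a 1.4-fold lower number from compound 1 to compound 2 (0.14 log units; within the scatter) lies within the scatter, so compound 2 and compound 1 cannot be told apart on these two numbers; compound 2 simply holds one of the two values recorded.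

Compound 3 `Cc1ccc(-c2nc3c(=O)n(C)c(=O)n(C)c3[nH]2)cc1` arises from compound 2 by the change (methyl in place of iodo on an aromatic carbon). Among the compounds with values here, the only measured step that touches this carbon is the one from compound 1 to compound 2, a 1.4-fold lower number from compound 1 to compound 2 (0.14 log units; within the scatter), and it stayed within the scatter. Within the data shown here, no measured step covers a methyl group, so the expectation rests on that one step alone, and the step to compound 3 is estimated as a 1.9-fold higher number from compound 2 to compound 3 (0.28 log units; within the scatter), no more than the scatter. Compound 3 is therefore expected to give 2.5 nM in this assay, within a range from 0.8 nM to 8 nM.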

Compound 3, half-maximal inhibitory concentration: 0.8 nM
Compound 3: middle estimate off by 3.1-fold (0.49 log units), on the high side; low and high end bracket the measured number.
By their numbers in this assay, from the lowest: compounds 3, 2 and 1 (each within the scatter of the next, the first and the last beyond it).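

With a methyl group on the aromatic carbon para to a large group, this position gives its first step beyond the scatter in this assay (a 2.3-fold lower number from compound 1 to compound 3 (0.35 log units; beyond the scatter)), although that step is modest and comes from methyl in place of dimethylamino. Methyl in place of iodo gives a 1.6-fold lower number from compound 2 to compound 3 (0.21 log units; within the scatter) and so stays within the scatter, which means that compound 2 cannot be told apart from compound 3, just as it could not be told apart from compound 1. Iodo therefore sits within the scatter of both other groups, only methyl and dimethylamino separate, and nothing given here explains that separation.

The compounds shown leave open whether the narrow spread seen with methyl, iodo and dimethylamino would hold for a carboxylic acid, a hydroxyl group, a primary amine or a longer alkyl chain at the same carbon. They also leave open whether methyl in place of dimethylamino would give a similar step on a different core or at another carbon of the same ring.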